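Working notes: amine substituent variation and cell toxicity

The source may report more compounds than this note shows. Statements on the series, on what has been measured and on what is new or still open speak of the compounds shown alone.

Measured compounds in a functional assay on HEL cells (Homo sapiens); on this read-out lower numbers stand for higher toxicity in this test and higher numbers for lower toxicity in this test:
compound 1 `Cc1cn([C@@H]2O[C@H](CO[Si](C)(C)C(C)(C)C)[C@@]3(OS(=O)(=O)C=C3NCCC(N)=O)[C@H]2O[Si](C)(C)C(C)(C)C)c(=O)n(C)c1=O`: 14800 nM
compound 2 `Cc1cn([C@@H]2O[C@H](CO[Si](C)(C)C(C)(C)C)[C@@]3(OS(=O)(=O)C=C3NC(N)=O)[C@H]2O[Si](C)(C)C(C)(C)C)c(=O)n(C)c1=O`: 11000 nM
compound 3 `COC(=O)CNC1=CS(=O)(=O)O[C@@]12[C@@H](CO[Si](C)(C)C(C)(C)C)O[C@@H](n1cc(C)c(=O)n(C)c1=O)[C@@H]2O[Si](C)(C)C(C)(C)C`: 160000 nM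

Compound 1 holds the second highest of the three numbers in this assay. Its nearest neighbour is compound 2, with a 1.3-fold lower number from compound 1 to compound 2 (0.13 log units; within the scatter), so the two are not distinguishable here. The furthest is compound 3, with an 11-fold higher number from compound 1 to compound 3 (1.03 log units; beyond the scatter). The step of a 15-fold higher number from compound 2 to compound 3 (1.16 log units; beyond the scatter) points the same way.

Compound 4 `Cc1cn([C@@H]2O[C@H](CO[Si](C)(C)C(C)(C)C)[C@@]3(OS(=O)(=O)C=C3NCC(=O)C(=O)O)[C@H]2O[Si](C)(C)C(C)(C)C)c(=O)n(C)c1=O` is not yet measured. It differs from compound 1 as follows: carboxycarbonyl in place of carbamoylmethyl on a saturated chain carbon bound to an amine nitrogen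

The step that bears on this most directly is an 11-fold higher number from compound 1 to compound 3 (1.03 log units; beyond the scatter), since it changes the same saturated chain carbon bound to the amine nitrogen and replaces the same carbamoylmethyl group. The step of a 15-fold higher number from compound 2 to compound 3 (1.16 log units; beyond the scatter) shows a comparable size for a related exchange. The step of a 1.3-fold lower number from compound 1 to compound 2 (0.13 log units; within the scatter), which alters only the group on the amine nitrogen, gives no shift beyond the scatter. Going by the values given here, only one analogue at the relevant carbon exists, so the size is uncertain, but a rise in this assay is expected rather than a fall.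

For compound 4 the estimate in this assay is 45000 nM, within a range from 14000 nM to 150000 nM, corresponding to an expected step of a 3.0-fold higher number from compound 1 to compound 4 (0.48 log units; beyond the scatter).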

Compound 4, half-maximal cytotoxic concentration: 146000 nM
Compound 4: middle estimate off by 3.2-fold (0.51 log units), on the low side; the measured number falls inside the stated range.
By their numbers in this assay, from the lowest: compounds 2 and 1 (each within the scatter of the next); then compounds 4 and 3 (each within the scatter of the next).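

In this assay, carboxycarbonyl in place of carbamoylmethyl on a saturated chain carbon bound to an amine nitrogen gives a 9.9-fold higher number from compound 1 to compound 4 (0.99 log units; beyond the scatter) and the wider exchange on the amine nitrogen gives a 13-fold higher number from compound 2 to compound 4 (1.12 log units; beyond the scatter) in the same direction, so the high number of compound 3 is no longer a single case at this carbon. Carboxy in place of methoxy on a carbonyl carbon gives a 1.1-fold lower number from compound 3 to compound 4 (0.04 log units; within the scatter) and leaves compound 3 and compound 4 indistinguishable in this test, so among the compounds shown this exchange on the carbonyl carbon does not separate the two. No measured property is available to account for the difference between these two compounds and compound 1 or compound 2.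

Two compounds with high numbers do not show whether the rise depends on the carbonyl-bearing end groups they carry or merely on the loss of the carbamoyl end group. As far as these compounds go, a simple primary amine, a hydroxyl or a longer chain ending in a carboxylic acid at the same carbon would test this, and the effect of such groups on the number in this assay remains open.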